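Aryl swap on the oxindole series: compound 1 to compound 4

The source may report more compounds than this note shows. Statements on the series, on what has been measured and on what is new or still open speak of the compounds shown alone.

Measured so far:
compound 1 `Cc1cc2c(cc1Cl)NC(=O)C2(NC(=O)CN1CCN(C)CC1)c1cccc(Cl)c1`, 1180 nM
compound 2 `C=CCN1CCN(CC(=O)NC2(c3ccc(Cl)c(Cl)c3)C(=O)Nc3cc(Cl)cc(Cl)c32)CC1`, 38 nM
compound 3 `CN(C)CCN(C)CC(=O)NC1(c2ccc(Cl)cc2)C(=O)Nc2cc(Cl)c(Cl)cc21`, > 10000 nM

All three were run in an in vitro functional assay on CHO-CREluc cells for antagonist activity at growth hormone secretagogue receptor type 1 (Homo sapiens), read by a luciferase reporter, with a stated time of 4 h; on this read-out lower numbers stand for stronger inhibition and higher numbers for weaker inhibition. Compound 1 has the higher of the two numbers reported; compound 2 sits a long way beneath it, and that gap is well beyond the scatter of this assay. The value for compound 3 is a limit, not a number; it is the limit given at the limit of > 10000 nM in this assay, at which 1 of the 3 values shown sits. Compound 2 and compound 3 differ from compound 1 in several places at once. Among the measured compounds shown here, no single step is isolated among the measured compounds, and their values are taken only as they stand.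

The next compound, compound 4 `COc1ccc(C2(NC(=O)CN3CCN(C)CC3)C(=O)Nc3cc(Cl)c(C)cc32)cc1`, keeps the core of compound 1 and the methylpiperazinyl acetamide side chain. The change is 4-methoxyphenyl in place of 3-chlorophenyl on a saturated ring carbon — 4-methoxyphenyl in place of 3-chlorophenyl on a saturated ring carbon. Nothing measured here speaks to this particular swap. Given that compound 1 already sits at the weak end of the numbers shown, the expectation is for a moderate step in this assay from compound 1 to compound 4 of a 2.1-fold higher number from compound 1 to compound 4 (0.33 log units; beyond the scatter), toward weaker inhibition. Compound 4 is therefore estimated at 2500 nM, with a range of 800 nM to 8000 nM.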

Compound 4, half-maximal inhibitory concentration: 525 nM
The estimate for compound 4 lay 4.8-fold (0.68 log units) above the measured number; measured number below the stated range.
By their numbers in this assay, from the lowest: compound 2; then compound 4; then compound 1. At a limit, above all of these: compound 3.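

In this assay, holding the core of compound 1 and the methylpiperazinyl acetamide side chain while placing 4-methoxyphenyl in place of 3-chlorophenyl on a saturated ring carbon gives a 2.2-fold lower number from compound 1 to compound 4 (0.35 log units; beyond the scatter), the only single change that can be read among the compounds shown. This position therefore accepts an aryl group without chlorine, and with one hydrogen-bond acceptor where 3-chlorophenyl has none, with no loss of inhibition; the step is modest and points toward stronger inhibition. No measured property among the data shown bears on why the number moves with this swap.

Among the compounds shown here, the single step leaves open whether it belongs to the methoxy group itself or to its place on the phenyl ring, and how 3-methoxyphenyl, 4-hydroxyphenyl or a pyridyl ring would read at this carbon on the same core. Also open, as far as these compounds go, is whether the swap carries over to the other side chains and chlorine patterns of compound 2 and compound 3, which differ from compound 1 in several places at once and give no reading of it.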